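Swapping the Bromophenyl Arm for a Dichlorophenyl One

The compounds below may be only part of what the source reports. "The series", "measured", "known", "first", "only" and "open" are said of these compounds alone.

Of the compounds shown here, three on a shared hydroxamic acid core have been tested in an assay on isolated protein for inhibition of bone morphogenetic protein 1 (Homo sapiens); on this read-out lower numbers stand for stronger inhibition and higher numbers for weaker inhibition. Compound 1 `COc1ccc(S(=O)(=O)N(Cc2ccc(Cl)c([N+](=O)[O-])c2)[C@H](C)C(=O)NO)cc1` gives 30 nM, compound 2 `COc1ccc(S(=O)(=O)N(CCn2cccc2)[C@H](C)C(=O)NO)cc1` gives 170 nM, and compound 3 `COc1ccc(S(=O)(=O)N(Cc2cccc(Br)c2)[C@H](C)C(=O)NO)cc1` gives 93 nM. Compound 3 therefore sits second highest of the three numbers: its step from compound 2 is a 1.8-fold lower number from compound 2 to compound 3 (0.26 log units; within the scatter), while compound 1 stands beyond the scatter at a lower number.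

Compound 4 `COc1ccc(S(=O)(=O)N(Cc2ccc(Cl)c(Cl)c2)[C@H](C)C(=O)NO)cc1` differs from compound 3 in one place: 3,4-dichlorophenyl in place of 3-bromophenyl on a saturated chain carbon bound to a sulfonamide nitrogen. Within the data shown here, no measured pair shows this exact swap of one halogen-bearing ring for another. Among the measured compounds shown here, the only step available, a 1.8-fold lower number from compound 2 to compound 3 (0.26 log units; within the scatter), concerns a different exchange and lies within the scatter, so it gives no firm direction. Compound 1, whose ring also carries two substituents, gives 30 nM, the lowest number seen, which hints that a second ring substituent may help. The expected step is a 2.1-fold lower number from compound 3 to compound 4 (0.32 log units; beyond the scatter), a modest move toward a lower number. Compound 4 is estimated at 45 nM, with a likely range from 15 nM to 130 nM.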

Compound 4, half-maximal inhibitory concentration: 120 nM
The estimate for compound 4 lay 2.7-fold (0.43 log units) below the measured number; the range from low to high includes it.
By their numbers in this assay, from the lowest: compound 1; then compounds 3, 4 and 2 (each within the scatter of the next).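

In this assay, 3,4-dichlorophenyl in place of 3-bromophenyl on a saturated chain carbon bound to a sulfonamide nitrogen gives no change beyond the scatter (a 1.3-fold higher number from compound 3 to compound 4 (0.11 log units; within the scatter)), and compound 4 also cannot be told apart from compound 2, which carries (1H-pyrrol-1-yl)methyl at this place (a 1.4-fold lower number from compound 2 to compound 4 (0.15 log units; within the scatter)). The one clear difference is with compound 1, where chloro in place of nitro on an aromatic carbon gives a 4.0-fold higher number from compound 1 to compound 4 (0.60 log units; beyond the scatter), so a second ring substituent alone does not give the lower number, and which group it is counts. Nothing measured here explains this difference.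

On these data alone, whether a nitrile or a carboxylic acid in place of that nitro would follow compound 1 or compound 4 stays open. So does the effect of a longer chain carrying the 3,4-dichlorophenyl ring.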